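Extending a sulfonyl aryl group in a bradykinin B1 series

The source may report more compounds than this note shows. Statements on the series, on what has been measured and on what is new or still open speak of the compounds shown alone.

Measured compounds:
- compound 1, `CC(C)(C)NCc1ccc2c(c1)CCC[C@H]2NC(=O)C[C@@H]1CCCCN1S(=O)(=O)c1ccccc1`, 1700 nM
- compound 2, `CC(C)(C)NCc1ccc2c(c1)CCC[C@H]2NC(=O)C[C@@H]1CCCCN1S(=O)(=O)c1cccc(Cl)c1`, 120 nM

In an assay on isolated protein for inhibition of B1 bradykinin receptor (Homo sapiens) (on this read-out higher numbers stand for weaker inhibition and lower numbers for stronger inhibition), compound 2 gives 120 nM, the lowest of the two numbers; its nearest neighbour is compound 1 with 1700 nM. Compound 3, `Cc1ccc(S(=O)(=O)N2CCCC[C@H]2CC(=O)N[C@@H]2CCCc3cc(CNC(C)(C)C)ccc32)cc1C(F)(F)F`, carries the change (4-methyl-3-(trifluoromethyl)phenyl in place of 3-chlorophenyl on a sulfonyl sulfur). Going by the values given here, the one measured step that bears on this, a 14-fold lower number from compound 1 to compound 2 (1.15 log units; beyond the scatter), shows that substituting the phenyl on the sulfonyl sulfur matters a great deal in this assay. Among the compounds with values here, the entering 4-methyl-3-(trifluoromethyl)phenyl keeps a substituted ring, now with a trifluoromethyl and a methyl, so no return toward compound 1 is expected, but the data hold no second example of such a ring, so the size of any further gain is uncertain. For compound 3 the expected step is a 1.5-fold lower number from compound 2 to compound 3 (0.18 log units; within the scatter), i.e. an estimated 80 nM, within 25 nM to 300 nM.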

Compound 3, half-maximal inhibitory concentration: 11 nM
Beside the measured number, compound 3's estimate is 7.3-fold (0.86 log units) above it; measured number below the stated range.
By their numbers in this assay, from the lowest: compound 3; then compound 2; then compound 1.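

In this assay, the position on the sulfonyl sulfur still responded strongly once the ring was already substituted: 4-methyl-3-(trifluoromethyl)phenyl in place of 3-chlorophenyl gave an 11-fold lower number from compound 2 to compound 3 (1.04 log units; beyond the scatter), so the 3-chlorophenyl of the earlier pair was not the limit of this position. Taken from the unsubstituted phenyl, the same position gave a 150-fold lower number from compound 1 to compound 3 (2.19 log units; beyond the scatter), and the ring entering here, with 11 heavy atoms against 7 in the one it replaced, gave the lowest number of the three. No measurement on hand accounts for this gain.

Going by these compounds, it remains open whether the trifluoromethyl or the methyl carries the step, since a 3-(trifluoromethyl)phenyl or a 4-methylphenyl alone could behave quite differently. On these data alone, how a phenyl bearing a nitrile or a methoxy group would fare on the same sulfonyl sulfur also stays unknown.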